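Moving a ring nitrogen in the shared core

A few compounds are considered here, and "the series" means these few. Any claim that something is new, unique, unknown or untested is made for them only; others in the source may bear on it.

Measured compounds:
compound 1 `O=C(Nc1ccc(-n2ncc3c(Cl)cccc32)cc1)Nc1ccc(Cl)c(C(F)(F)F)c1` — 3100 nM
compound 2 `Cc1cccc2c1cnn2-c1ccc(NC(=O)Nc2ccc(Cl)c(C(F)(F)F)c2)cc1` — 32000 nM
compound 3 `O=C(Nc1ccc(-n2ncc3ccncc32)cc1)Nc1ccc(Cl)c(C(F)(F)F)c1` — > 32000 nM

In a functional assay on OS-RC-2 cells (Homo sapiens) for cytotoxicity, read by MTT assay, with a stated time of 72 h (a lower number here means a stronger inhibitor, a higher number a weaker inhibitor), compound 1 gives 3100 nM. Compound 2 gives 32000 nM in this assay, a step of a 10-fold higher number from compound 1 to compound 2 (1.01 log units; beyond the scatter). For compound 3 only a limit is known, > 32000 nM, so compound 3 sits at the weak end of the three, at the limit of > 32000 nM in this assay, at which 1 of the 3 values shown sits. The step of an at least 10-fold higher number from compound 1 to compound 3 (1.01 log units; beyond the scatter) shows that putting a six-membered ring with one hetero atom into the shared core costs strongly, and a number no lower from compound 2 to compound 3 (the limit leaves the size open) is at least no gain.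

Compound 4 `O=C(Nc1ccc(-n2ncc3cccnc32)cc1)Nc1ccc(Cl)c(C(F)(F)F)c1` is not yet measured. It differs from compound 3 by a group of 9 heavy atoms (6 carbon, 3 nitrogen; one five-membered aromatic ring with 2 hetero atoms, one six-membered aromatic ring with 1 hetero atom) in place of a group of 9 heavy atoms (6 carbon, 3 nitrogen; one five-membered aromatic ring with 2 hetero atoms, one six-membered aromatic ring with 1 hetero atom), on an aromatic carbon; the two have the same atoms joined differently. Going by the values given here, no measured step shows what moving the nitrogen within the six-membered ring does; the steps from compound 1 and compound 2 only show that such a ring, as in compound 3, is weak. Compound 4 is therefore expected to stay weak, with an estimated step of an at least 1.0-fold lower number from compound 3 to compound 4 (0.02 log units; that floor lies within the scatter), and its value in this assay is estimated at 30000 nM, between 8000 nM and 100000 nM.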

Compound 4, half-maximal inhibitory concentration: > 32000 nM
Compound 4: only a limit was reported (the forecaster's own chance of this, stated with the estimate: 55%); at least 1.0-fold (0.02 log units) between middle value and limit.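

Compound 4, like compound 3, stands only at a limit in this assay, so both placements of the nitrogen in the six-membered ring of the shared core end up at the same limit: the limit of > 32000 nM in this assay, at which 2 of the 4 values shown sit. Moving the nitrogen therefore brings back no measurable activity, and the loss stays large, with an at least 10-fold higher number from compound 1 to compound 4 (1.01 log units; beyond the scatter). Replacing the methyl-bearing core brings no gain either, with a number no lower from compound 2 to compound 4 (the limit leaves the size open). The step from compound 3 to compound 4 cannot be read, so the two nitrogen placements cannot be ranked against each other.

What the compounds shown leave open is what a fluoro, methoxy or amino group would give in place of the chloro of compound 1. They also leave open whether a chloro on a core with a ring nitrogen would restore a readable value.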